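Shortening the branched substituent of compound 2

This account rests on a few compounds, and the source may have more. Where it says the series, first, only, none or still open, it means among the compounds named here.

Of the compounds shown here, three sharing one core have been measured in a functional assay on Right cardiac atrium for agonist activity at histamine H2 receptor (Cavia porcellus), with a stated time of 30 min, in the presence of a further agent that is not named here; on this read-out lower numbers stand for smaller maximal responses and higher numbers for larger maximal responses. Compound 1 `Cc1nc(N)sc1CCCN/C(N)=N/C(=O)NC(C)c1ccc(Br)cc1` gives 0.87, compound 3 `Cc1nc(N)sc1CCCN/C(N)=N/C(=O)NC(C)c1cccs1` gives 0.88, and compound 2 `Cc1nc(N)sc1CCCN/C(N)=N/C(=O)NC(c1ccccc1)C(C)C` gives 1.04. Compound 2 stands highest of the three; its gaps to compound 3 and to compound 1 both lie beyond the scatter. Among the measured compounds shown here, the only step between measured compounds that differ in one place, a number 0.010 higher from compound 1 to compound 3 (within the scatter), exchanges the aryl group on a saturated chain carbon bound to an amide-type nitrogen and a saturated chain carbon, and it was within the scatter.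

Compound 4 `CCC(NC(=O)/N=C(\N)NCCCc1sc(N)nc1C)c1ccccc1` differs from compound 2 by hydrogen in place of methyl on a saturated chain carbon bound to two saturated chain carbons. For the measured compounds named here, no measured step touches this branch; the one step recorded, a number 0.010 higher from compound 1 to compound 3 (within the scatter), concerns another site and was flat, so nothing points to a large move in either direction. The step in this assay is therefore expected to be small, a number 0.040 lower from compound 2 to compound 4 (within the scatter), not beyond the scatter. Compound 4 is estimated at 1, with a range from 0.88 to 1.1.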

Compound 4, intrinsic activity: the largest response reached, as a fraction of the reference agonist's: 0.93
The estimate for compound 4 lay 0.070 above the measured number; low and high end bracket the measured number.
By their numbers in this assay, from the lowest: compounds 1, 3 and 4 (each within the scatter of the next); then compound 2.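

In this assay, among the compounds shown here, this branch is the first site where a single change clearly moves the maximal response: isopropyl to ethyl gives a number 0.11 lower from compound 2 to compound 4 (beyond the scatter), while the aryl exchange gave only a number 0.010 higher from compound 1 to compound 3 (within the scatter). One methyl, a single carbon with no ring, no hydrogen-bond donor or acceptor and no net charge, is therefore enough to produce a modest step at this place. Nothing available here accounts for that step.

The compounds shown leave open how a tert-butyl, a cyclohexyl or a longer chain such as n-butyl would behave on this saturated chain carbon, and so whether the response follows the size of the group at all. Going by these compounds, it also remains open whether the same isopropyl to ethyl step appears with 4-bromophenyl or thiophen-2-yl as the aryl group.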